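Benzylselanyl in Place of Methylsulfanyl on a Shared Core

This account rests on a few compounds, and the source may have more. Where it says the series, first, only, none or still open, it means among the compounds named here.

Measured so far:
compound 1, `CS/C(=N\C(=O)c1ccno1)NC(=O)c1ccno1` — > 100000 nM
compound 2, `C[Se]/C(=N\C(=O)c1ccco1)NC(=O)c1ccco1` — > 100000 nM
compound 3, `CS/C(=N\C(=O)c1cc2ccccc2s1)NC(=O)c1cc2ccccc2s1` — 75800 nM

In a functional assay on HepG2 cells (Homo sapiens) for cytotoxicity, read by MTT assay, with a stated time of 72 h (on this read-out lower numbers stand for higher toxicity in this test and higher numbers for lower toxicity in this test), compound 1 gives only a limit of the assay, > 100000 nM. Compound 2 likewise gives only a limit, > 100000 nM. For the measured compounds named here, compound 3 is the one compound of the three with a measured number, 75800 nM. Going by the values given here, compound 1 therefore stands at the limit of > 100000 nM in this assay, at which 2 of the 3 values shown sit, and no two measured compounds in this set differ in a single place, so no measured step can be stated.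

Compound 4, `O=C(/N=C(/NC(=O)c1ccno1)[Se]Cc1ccccc1)c1ccno1`, has not yet been tested in this assay. It differs from compound 1 by a group of 8 heavy atoms (7 carbon, 1 selenium; one six-membered aromatic ring of carbon only) in place of a group of 2 heavy atoms (1 carbon, 1 sulfur; no ring), on a carbon with a double bond to nitrogen. Compound 2 shows that a selenium in the same place, with a small methyl on it, still gives only a limit, while compound 3 shows that a larger set of aromatic rings on the core gives a number close to the limit. The change from compound 1 to compound 4 is expected to shift the read-out little, if at all, beyond the scatter, and the expected step is an at least 1.2-fold lower number from compound 1 to compound 4 (0.09 log units; that floor lies within the scatter). Compound 4 is thus expected to give about 80000 nM in this assay, within a range from 30000 nM to 300000 nM, with a real chance that only a limit is reported again.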

Compound 4, concentration lethal to 50% of the cells: > 100000 nM
Compound 4 was reported as a limit (the forecaster's own chance of this, stated with the estimate: 50%); middle value at least 1.2-fold (0.09 log units) from the limit.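

For the compounds shown here, compound 4 and compound 1 are each reported only as a limit, so no step between them can be read. The set now stands as follows: the limit of > 100000 nM in this assay, at which 3 of the 4 values shown sit.

The compounds shown leave open whether placing the larger selenium-bearing group on the carbon with a double bond to nitrogen changes the cell toxicity at all, and by how much.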